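The source may report more compounds than this note shows. Statements on the series, on what has been measured and on what is new or still open speak of the compounds shown alone.

Series notes. Compound 1 `CS(=O)(=O)c1ccc(C(=O)N2CCC(n3cncc3-c3ccc(OS(=O)(=O)c4cccc(C#N)c4)cc3)CC2)cc1` and compound 2 `N#Cc1cccc(S(=O)(=O)Oc2ccc(-c3cncn3C3CCN(C(=O)c4ccc([N+](=O)[O-])cc4)CC3)cc2)c1` share one core; compound 3 `CS(=O)(=O)c1ccc(C(=O)N2CCC(c3nc4cc(OS(=O)(=O)c5cccc6cnccc56)ccc4[nH]3)CC2)cc1` is built on another, and the difference between the two cores is not broken down here. In an assay on HEK293 cells for antagonist activity at P2X purinoceptor 7 (Homo sapiens), read by fluorescence, with a stated time of 2 h (a lower number here means a stronger inhibitor, a higher number a weaker inhibitor), compound 1 gives 143 nM, compound 2 gives 45 nM and compound 3 gives 7 nM, the lowest of the three numbers. The change from compound 1 to compound 2 is nitro in place of methylsulfonyl on an aromatic carbon, and it made a 3.2-fold lower number from compound 1 to compound 2 (0.50 log units; beyond the scatter). Compound 4 `O=C(c1ccc([N+](=O)[O-])cc1)N1CCC(c2nc3cc(OS(=O)(=O)c4cccc5cnccc45)ccc3[nH]2)CC1` carries the same change on the core of compound 3: nitro in place of methylsulfonyl on an aromatic carbon. The step in this assay is expected to be a 2.3-fold lower number from compound 3 to compound 4 (0.37 log units; beyond the scatter), about as large as the earlier one, because only a 3.2-fold lower number from compound 1 to compound 2 (0.50 log units; beyond the scatter) is available as a precedent and it comes from a different core, so the range is kept wide. Compound 4 is estimated at 3 nM, between 1.2 nM and 8 nM.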

Compound 4, half-maximal inhibitory concentration: 13 nM
Beside the measured number, compound 4's estimate is 4.3-fold (0.64 log units) below it, and the stated range ends below it.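

In this assay, nitro in place of methylsulfonyl gives a 1.9-fold higher number from compound 3 to compound 4 (0.27 log units; within the scatter), so on this core the two groups cannot be told apart, whereas on the core of compound 1 they can. The step therefore does not carry over unchanged from one core to the other: the same change on two cores in this assay, a 3.2-fold lower number (0.50 log units; beyond the scatter) from compound 1 to compound 2 and a 1.9-fold higher number (0.27 log units; within the scatter) from compound 3 to compound 4, 5.9-fold (0.77 log units) apart, beyond the scatter of two such steps

With one pair on each core, these data do not show which part of the difference between the cores goes with this divergence, or how the change would behave on any further core. Left open is whether an amine or a carboxylic acid on the same aromatic carbon would also give steps that differ between the two cores.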